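Replacing a chloro by hydrogen on purine-like cores

The source may hold more compounds than are shown below. What is called first, only, known or untested is meant among the compounds shown, and "the series" means these compounds.

Three compounds were measured in a functional assay on CAKI-1 cells (Homo sapiens) for cytotoxicity, read by sulforhodamine B assay, with a stated time of 48 h; a lower number here means a stronger inhibitor of growth, a higher number a weaker inhibitor of growth:

compound 1, `ClCc1ccccc1Cn1cnc2c(Cl)nc(Cl)nc21`, gives 360 nM
compound 2, `ClCc1ccccc1Cn1cnc2c(Cl)ncnc21`, gives 1820 nM
compound 3, `ClCc1ccc(Cn2cnc3nc(Cl)nc(Cl)c32)cc1`, gives 1440 nM

Compound 1 and compound 2 share a core and differ by hydrogen in place of chloro on an aromatic carbon, a change that produced a 5.1-fold higher number from compound 1 to compound 2 (0.70 log units; beyond the scatter). Compound 3 has the same atoms as compound 1 joined differently; the difference between the two cores is not broken down here. The values of compound 2 and compound 3 lie within the usual scatter of each other, so nothing separates them.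

Compound 4, `ClCc1ccc(Cn2cnc3ncnc(Cl)c32)cc1`, is not yet measured. It differs from compound 3 by hydrogen in place of chloro on an aromatic carbon, and the surroundings of the place match those of the change between compound 1 and compound 2 word for word, so this is the same change. Within the data shown here, for compound 4 a weakening step of a 4.9-fold higher number from compound 3 to compound 4 (0.69 log units; beyond the scatter) is expected, because the matching change produced a 5.1-fold higher number from compound 1 to compound 2 (0.70 log units; beyond the scatter) and only this one example is available. Compound 4 is therefore estimated at 7000 nM, most likely between 2500 nM and 20000 nM.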

Compound 4, concentration for 50% growth inhibition: 1990 nM
The estimate for compound 4 lay 3.5-fold (0.55 log units) above the measured number; the measured number lies below the stated range.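

In this assay, putting hydrogen in place of the chloro on the aromatic carbon between two ring nitrogen atoms gave a 1.4-fold higher number from compound 3 to compound 4 (0.14 log units; within the scatter), so compound 3 and compound 4 cannot be told apart. Set beside the earlier example, the same change did not carry over from one core to the other with the same size: the same change on two cores in this assay, a 5.1-fold higher number (0.70 log units; beyond the scatter) from compound 1 to compound 2 and a 1.4-fold higher number (0.14 log units; within the scatter) from compound 3 to compound 4, 3.7-fold (0.56 log units) apart, beyond the scatter of two such steps This shows that, in this series, a step seen on one core is not a safe guide to the step on another, but two cores are too few for a rule, and the numbers do not show what in the cores separates the two results.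

The compounds shown have only chloro or hydrogen at this place, so it remains open how an amine, a methoxy group or a longer chain there would fare in this assay. On these data alone, it also remains open whether this change on further cores would give a large step, as on the core of compound 1, or one within the scatter, as on the core of compound 3.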